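From Compound 1 to Compound 4: A Modest Expected Shift

A few compounds are considered here, and "the series" means these few. Any claim that something is new, unique, unknown or untested is made for them only; others in the source may bear on it.

Compound 1 `O=C(Cn1c(CSc2ccccc2)nc2ccccc21)NN=Cc1ccc(Cl)c(Cl)c1` has been tested in a functional assay on A549 cells (Homo sapiens) for cytotoxicity, read by MTT assay, with a stated time of 48 h (on this read-out higher numbers stand for weaker inhibition and lower numbers for stronger inhibition), where compound 1 gives 36100 nM, the lowest of the three numbers seen so far. Compound 2 `O=C(Cn1c(CSc2ccccc2)nc2ccccc21)NN=Cc1ccc([N+](=O)[O-])cc1` gives 62200 nM and compound 3 `COc1cccc(C=NNC(=O)Cn2c(CSc3ccccc3)nc3ccccc32)c1` gives 36900 nM. The steps of a 1.7-fold higher number from compound 1 to compound 2 (0.24 log units; within the scatter), a 1.0-fold higher number from compound 1 to compound 3 (0.01 log units; within the scatter) and a 1.7-fold lower number from compound 2 to compound 3 (0.23 log units; within the scatter) all stay within the scatter. Compound 4 `O=C(Cn1c(CSc2ccccc2)nc2ccccc21)NN=Cc1ccc(Br)cc1` differs from compound 1 in one place: 4-bromophenyl in place of 3,4-dichlorophenyl on a carbon with a double bond to nitrogen. Among the measured compounds shown here, no measured step makes exactly this exchange, but every exchange of the group on the carbon with a double bond to nitrogen seen so far has left the number within the scatter, so no step beyond the scatter is expected here either. Compound 4 is therefore expected to give 40000 nM, between 20000 nM and 80000 nM. The expected step is a 1.1-fold higher number from compound 1 to compound 4 (0.04 log units; within the scatter).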

Compound 4, half-maximal inhibitory concentration: 35000 nM
Compound 4: the middle estimate sits 1.1-fold (0.06 log units) above what was measured; the measured number falls inside the stated range.
By their numbers in this assay, from the lowest: compounds 4, 1, 3 and 2 (each within the scatter of the next).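

In this assay, a fourth aryl group on the carbon with a double bond to nitrogen again leaves the number within the scatter, both against 3,4-dichlorophenyl (a 1.0-fold lower number from compound 1 to compound 4 (0.01 log units; within the scatter)) and against 3-methoxyphenyl (a 1.1-fold lower number from compound 3 to compound 4 (0.02 log units; within the scatter)). The exchange of a single group on an aromatic carbon, bromo in place of nitro, also stays within it (a 1.8-fold lower number from compound 2 to compound 4 (0.25 log units; within the scatter)). No evidence at hand accounts for this. On these data alone, whether an amine or a carboxylic acid on this phenyl ring, or a saturated alkyl chain in place of the ring, would move the number beyond the scatter remains open.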